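Adding Methylsulfonyl to the Shared Core of Compound 1

A few compounds are considered here, and "the series" means these few. Any claim that something is new, unique, unknown or untested is made for them only; others in the source may bear on it.

Compound 1 has the structure `O=c1c(-c2nn[nH]n2)c[nH]c2ccccc12`. In a functional assay on the whole organism (strain Sprague-Dawley) for inhibition, with Rattus norvegicus as the target (on this read-out lower numbers stand for an effect already at smaller amounts and higher numbers for an effect only at larger amounts of compound), compound 1 gives only a limit of the assay, > 20 mg/kg, so its true dose is not known. Two compounds share its core with one change each. Compound 2, `O=c1c(-c2nn[nH]n2)c[nH]c2ccc(Cl)cc12`, in this assay also gives only a limit, > 25 mg/kg. Compound 3, `O=c1c(-c2nn[nH]n2)c[nH]c2ccc(F)cc12`, in this assay likewise gives only a limit, > 20 mg/kg. The step that the two limits leave unreadable from compound 1 to compound 2 cannot be read because each of its two values is a limit, and the same holds for a step that the two limits leave unreadable from compound 1 to compound 3 and a step that the two limits leave unreadable from compound 2 to compound 3. The picture is summed up by the limit of > 20 mg/kg in this assay, at which 2 of the 3 values shown sit, and the limit of > 25 mg/kg in this assay, at which 1 of the 3 values shown sits: no compound here has shown a measurable dose.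

Compound 4, `CS(=O)(=O)c1cccc2c(=O)c(-c3nn[nH]n3)c[nH]c12`, differs from compound 1 in one place: methylsulfonyl in place of hydrogen on an aromatic carbon. Going by the values given here, none of the measured steps bears on this change in a readable way, since each is hidden by a limit. The expectation for compound 4 therefore rests only on the three limits, and the estimated step that the limit leaves unreadable from compound 1 to compound 4 is taken as no change beyond the scatter. Compound 4 is expected in this assay to give about 25 mg/kg, within the range 8 mg/kg to 80 mg/kg, most likely again as a limit rather than a number.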

Compound 4, minimum effective dose: > 25 mg/kg
Compound 4: no number, only a limit; the forecaster's own chance of this, stated with the estimate: 70%; the middle value lies on the limit itself.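

In this assay compound 4 gives only a limit, > 25 mg/kg. Going by these compounds alone, compound 1 gives only a limit too, so the step from compound 1 to compound 4 cannot be read, any more than the earlier steps. The compounds shown leave open whether any change to the shared core gives a measurable dose: all four values are limits.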